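This account rests on a few compounds, and the source may have more. Where it says the series, first, only, none or still open, it means among the compounds named here.

Compound 1 `Cc1ccc(S(=O)(=O)Oc2ccccc2/C=C(\C#N)C(=O)Nc2nnc(Cc3ccc(F)cc3)s2)cc1` with 16%
Compound 2 `Cc1ccc(S(=O)(=O)Oc2ccccc2/C=C(\C#N)C(=O)Nc2nnc(Cc3cccc(F)c3)s2)cc1` with 9%

In an ADME assay on HEK-293T cells (Homo sapiens) for inhibition, read by CCK-8 assay, with a stated time of 48 h, tested at 20 uM (a higher number here means more inhibition of growth at the concentration tested, a lower number less inhibition of growth), compound 2 gives 9% and has only compound 1 for comparison. Between them lies a number 7 percentage points lower from compound 1 to compound 2 (within the scatter) so the two cannot be ranked.

Compound 3 `Cc1ccc(S(=O)(=O)Oc2ccccc2/C=C(\C#N)C(=O)Nc2nnc(Cc3ccc(Cl)cc3)s2)cc1` is still to be measured. Its difference from compound 2 is counted as follows: 4-chlorophenyl in place of 3-fluorophenyl on a saturated chain carbon bound to an aromatic carbon with 4-chlorophenyl in place of 3-fluorophenyl on a saturated chain carbon bound to an aromatic carbon.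

For the measured compounds named here, only one measured step bears on this change, the swap of 4-fluorophenyl for 3-fluorophenyl at the same place, which gave a number 7 percentage points lower from compound 1 to compound 2 (within the scatter) and so stayed small. Going by the values given here, no measured compound carries chlorine, so that part of the change is untested. No step beyond the scatter is therefore expected in this assay for this change.

The estimated change is a number 4 percentage points higher from compound 2 to compound 3 (within the scatter) and would not count as a real difference. For compound 3 the expected value is 13% with an estimated range from 3% to 28% as the likely spread.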

Compound 3, percent growth inhibition at one concentration: 20%
Compound 3: middle estimate off by 7 percentage points, on the low side; the range from low to high includes it.
By their numbers in this assay, from the lowest: compounds 2, 1 and 3 (each within the scatter of the next, the first and the last beyond it).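

In this assay, for the compounds shown here, the change from 3-fluorophenyl to 4-chlorophenyl on a saturated chain carbon bound to an aromatic carbon gives the first step at this position that lies beyond the scatter (a number 11 percentage points higher from compound 2 to compound 3 (beyond the scatter)). Chloro in place of fluoro on an aromatic carbon, with the halogen's ring position unchanged, gives a step within the scatter (a number 4 percentage points higher from compound 1 to compound 3 (within the scatter)), so the swap of halogen alone does not separate these two compounds. Nothing measured here speaks to the reason for either step.

A 3-chlorophenyl group would show whether the halogen and its ring position each matter, since the step from 3-fluorophenyl to 4-chlorophenyl changes both at once. As far as these compounds go, it also remains open how a methoxy group or an amine on the same ring would read.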